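Chloro added to the core of compound 1

The source may hold more compounds than are shown below. What is called first, only, known or untested is meant among the compounds shown, and "the series" means these compounds.

Compound 1 `ClCc1cccc(Cn2cnc3ncnc(Cl)c32)c1` gives 210 nM in a functional assay on T47D cells (Homo sapiens) for cytotoxicity, read by sulforhodamine B assay, with a stated time of 48 h (on this read-out higher numbers stand for weaker inhibition of growth and lower numbers for stronger inhibition of growth), the lowest of the two numbers measured there; compound 2 `ClCc1cccc(Cn2cnc3c(Cl)ncnc32)c1` gives 3020 nM in this assay, a higher number that lies beyond the scatter. Compound 3 `ClCc1cccc(Cn2cnc3nc(Cl)nc(Cl)c32)c1` differs from compound 1 by chloro in place of hydrogen on an aromatic carbon. Going by the values given here, no measured pair in this assay shows such a change, so the expected step is a 1.4-fold higher number from compound 1 to compound 3 (0.15 log units; within the scatter), small and not clearly beyond the scatter in either direction. Compound 3 is therefore estimated at 300 nM, with a range from 80 nM to 1200 nM.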

Compound 3, concentration for 50% growth inhibition: 220 nM
Compound 3: middle estimate off by 1.4-fold (0.13 log units), on the high side; measured number inside the range.
By their numbers in this assay, from the lowest: compounds 1 and 3 (each within the scatter of the next); then compound 2.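

In this assay, chloro in place of hydrogen on the aromatic carbon between two ring nitrogen atoms gives a 1.0-fold higher number from compound 1 to compound 3 (0.02 log units; within the scatter), so this position of the shared core carries a chloro group while growth inhibition stays level with that of compound 1. The compounds shown offer no measurement that accounts for this. As far as these compounds go, whether this position would also carry an amine, a methoxy group or a longer chain remains open, and so does whether a carboxylic acid there would leave compound 3's level of growth inhibition intact.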